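Swapping a propyl carbamate for a benzyl carbamate

A few compounds are considered here, and "the series" means these few. Any claim that something is new, unique, unknown or untested is made for them only; others in the source may bear on it.

Of the compounds shown here, two from one series have been measured in a functional assay on WI-38 VA13 cells (Homo sapiens) for cytotoxicity; on this read-out higher numbers stand for an effect only at larger amounts of compound and lower numbers for an effect already at smaller amounts. Compound 1 `NCCC(=O)Nc1nc2ccc(NC(=O)c3c(Cl)cccc3Cl)cc2s1` gives 5.3 ug/mL. Compound 2 `CCCOC(=O)Nc1nc2ccc(NC(=O)c3c(Cl)cccc3Cl)cc2s1` gives 0.0025 ug/mL, the lowest of the two numbers and far from compound 1: a 2100-fold lower number from compound 1 to compound 2 (3.33 log units; beyond the scatter). Compound 3 `O=C(Nc1nc2ccc(NC(=O)c3c(Cl)cccc3Cl)cc2s1)OCc1ccccc1` has not been measured; it differs from compound 2 by phenyl in place of ethyl on a saturated chain carbon bound to an oxygen next to a carbonyl group, so the carbamate that sets compound 2 apart from compound 1 is kept. Within the data shown here, the only measured step, from compound 1 to compound 2, changes the group on the carbonyl carbon itself and says little about a swap of ethyl for phenyl further out; no pair in the data probes that. Compound 3 is therefore expected to stay close to compound 2, with the step from compound 2 to compound 3 estimated as a 2.0-fold higher number from compound 2 to compound 3 (0.30 log units; within the scatter), giving an expected 0.005 ug/mL in this assay, within a range from 0.0005 ug/mL to 0.05 ug/mL.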

Compound 3, half-maximal effective concentration: 0.018 ug/mL
Compound 3: middle estimate off by 3.6-fold (0.56 log units), on the low side; low and high end bracket the measured number.
By their numbers in this assay, from the lowest: compound 2; then compound 3; then compound 1.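

Among these compounds, putting phenyl in place of ethyl on the outer end of the carbamate is the first change here at this position, and in this assay it gives a 7.2-fold higher number from compound 2 to compound 3 (0.86 log units; beyond the scatter) and so shows that this outer end is not indifferent to what sits there. The shift is modest beside a 290-fold lower number from compound 1 to compound 3 (2.47 log units; beyond the scatter) and leaves compound 3 much closer to compound 2 than to compound 1, which carries 2-aminoethyl on the carbonyl carbon. Nothing in the available data gives a reason for either step.

From the compounds shown here alone, it remains open whether a saturated ring such as cyclohexyl in place of the phenyl, or a longer chain such as pentyl in place of the ethyl, would fall nearer compound 2 or compound 3. Going by these compounds, the effect of a chlorine or an amine on the phenyl ring also remains open.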